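The compounds below may be only part of what the source reports. "The series", "measured", "known", "first", "only" and "open" are said of these compounds alone.

Compound 1 `O=C(COc1ccc2cc(/C=C3/SC(=O)NC3=O)ccc2c1)Nc1cccc(Cl)c1` gives 3800 nM in an assay on isolated protein for inhibition of histone deacetylase 4 (Homo sapiens), with a stated time of 1 h; on this read-out lower numbers stand for stronger inhibition and higher numbers for weaker inhibition.
Compound 2 `Cc1cccc(NC(=O)COc2ccc3cc(/C=C4/SC(=O)NC4=O)ccc3c2)n1` gives 1100 nM in this assay.
Compound 3 `O=C(COc1ccc2cc(/C=C3/SC(=O)NC3=O)ccc2c1)Nc1ccc(Br)cc1F` gives 1900 nM in this assay.

Among these three numbers, compound 3 stands second highest. Its nearest neighbour is compound 2, with a 1.7-fold higher number from compound 2 to compound 3 (0.24 log units; within the scatter), and the furthest is compound 1, with a 2.0-fold lower number from compound 1 to compound 3 (0.30 log units; within the scatter); both gaps lie within the scatter, so the three compounds cannot be ordered with confidence.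

Compound 4 `O=C(COc1ccc2cc(/C=C3/SC(=O)NC3=O)ccc2c1)Nc1ccccn1` is the next step from compound 3: pyridin-2-yl in place of 4-bromo-2-fluorophenyl on an amide-type nitrogen. The closest measured precedent is the change on the same amide-type nitrogen from compound 1 to compound 2, which replaced 3-chlorophenyl by 6-methylpyridin-2-yl and gave a 3.5-fold lower number from compound 1 to compound 2 (0.54 log units; beyond the scatter). The pyridin-2-yl of compound 4 differs from the 6-methylpyridin-2-yl of compound 2 only by the methyl group, so compound 4 is expected to land close to compound 2. Since compound 3 already sits within the scatter of compound 2, the step to compound 4 is expected to be small, in the lower direction, and not clearly beyond the scatter: a 1.5-fold lower number from compound 3 to compound 4 (0.16 log units; within the scatter). For compound 4 the estimate in this assay is 1300 nM, with a range from 600 nM to 2800 nM.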

Compound 4, half-maximal inhibitory concentration: 17000 nM
For compound 4 the middle estimate is 13-fold (1.12 log units) below the measured one; the measured number lies above the stated range.
By their numbers in this assay, from the lowest: compounds 2, 3 and 1 (each within the scatter of the next, the first and the last beyond it); then compound 4.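

Going by these compounds alone, the methyl group on the pyridin-2-yl ring turns out to matter far more than the earlier compounds could show: hydrogen in place of methyl on an aromatic carbon gives a 15-fold higher number from compound 2 to compound 4 (1.19 log units; beyond the scatter) in this assay, the largest step in the set and one made by a single small change. The pyridin-2-yl group alone therefore does not carry the gain seen in a 3.5-fold lower number from compound 1 to compound 2 (0.54 log units; beyond the scatter), since the unsubstituted ring falls behind both halogenated phenyl groups on the same amide-type nitrogen, with an 8.9-fold higher number from compound 3 to compound 4 (0.95 log units; beyond the scatter) and a 4.5-fold higher number from compound 1 to compound 4 (0.65 log units; beyond the scatter). At this position, then, the number follows the substitution on the ring and not simply the presence of a ring nitrogen, although no measurement shown here accounts for the size of these steps.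

The compounds shown leave open whether the recovery depends on methyl itself or would also occur with an ethyl, a methoxy or an amine on the same aromatic carbon. They also leave open how an unsubstituted phenyl on the amide-type nitrogen would compare with compound 4, which would separate the contribution of the ring nitrogen from that of the halogens.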